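The source may report more compounds than this note shows. Statements on the series, on what has been measured and on what is new or still open speak of the compounds shown alone.

Working notes on the series, read in an ADME assay on L02 cells (Homo sapiens) for cytotoxicity, read by MTT assay, with a stated time of 24 h (a higher number here means a weaker inhibitor, a lower number a stronger inhibitor), for now. Compound 1 (`O=C1/C(=C/c2cccnc2)CN(S(=O)(=O)c2ccc(Cl)cc2)C/C1=C\c1ccccc1F`) gives > 20000 nM as a limit of the assay and not a number. Within the data shown here, compound 2 (`O=C1/C(=C/c2ccncc2)CN(S(=O)(=O)c2ccc([N+](=O)[O-])cc2)C/C1=C\c1ccccc1F`) gives 18400 nM as the only actual number so far. The other result is a limit, so compound 2 has no numerical neighbour to be ranked against.

The next compound is compound 3 (`O=C1/C(=C/c2ccncc2)CN(S(=O)(=O)c2ccc(Cl)cc2)C/C1=C\c1ccccc1F`), which departs from compound 2 by a single change: chloro in place of nitro on an aromatic carbon. In words, this is chloro in place of nitro on an aromatic carbon, so 4-nitrophenyl becomes 4-chlorophenyl. Among the measured compounds shown here, no step between measured compounds is available to size this change. In this assay no shift beyond the usual scatter is expected, and neither direction is favoured. This expectation rests on compound 2, which at 18400 nM is already a weak inhibitor in these cells. The expected step, a 1.0-fold higher number from compound 2 to compound 3 (0.01 log units; within the scatter), stays small, and a result reported only as a limit would be no surprise. Compound 3 is estimated at 19000 nM, with an expected range from 9000 nM to 40000 nM.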

Compound 3, half-maximal inhibitory concentration: 15000 nM
The estimate for compound 3 lay 1.3-fold (0.10 log units) above the measured number, and the stated range covers the measured number.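

In this assay, among these compounds, 4-chlorophenyl in place of 4-nitrophenyl gives a 1.2-fold lower number from compound 2 to compound 3 (0.09 log units; within the scatter), the first sized change on this aromatic carbon, para to a large group, and nitro and chloro cannot be told apart here despite the loss of both hydrogen-bond acceptors and two heavy atoms. The pyridine attachment can now be read from one side only, with pyridin-4-yl in place of pyridin-3-yl on the double-bonded chain carbon giving an at least 1.3-fold lower number from compound 1 to compound 3 (0.12 log units; that floor lies within the scatter). Compound 1 stands at a limit of the assay and not a number, so this step has a floor and no size, and the floor shows no difference between the two pyridines: the limit of > 20000 nM in this assay, at which 1 of the 3 values shown sits.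

Still open, on these data alone, is whether an amine or a carboxylic acid on this aromatic carbon would move the number in this assay beyond the scatter, since only nitro and chloro are compared at this place. As far as these compounds go, the true size of the step between pyridin-3-yl and pyridin-4-yl also remains open, and so does whether a pyridin-2-yl group would differ from either.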